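From 4-acetylphenyl to chloromethyl on a shared core

This account rests on a few compounds, and the source may have more. Where it says the series, first, only, none or still open, it means among the compounds named here.

Measured in a functional assay on NCI-H460 cells (Homo sapiens) for cytotoxicity, read by MTT assay, with a stated time of 48 h; a lower number here means a stronger inhibitor, a higher number a weaker inhibitor:
- compound 1 `C=C1C(=O)O[C@H]2CC3=C[C@H](C/C(C)=C/[C@@H](OC(=O)c4ccc(C(C)=O)cc4)[C@H]12)OC3=O`: 2200 nM
- compound 2 `C=C1C(=O)O[C@H]2CC3=C[C@H](C/C(C)=C/[C@@H](OC(=O)c4ccc(-c5ccccc5)cc4)[C@H]12)OC3=O`: 3500 nM

For the measured compounds named here, compound 1 stands level with compound 2, the only other measured compound, and neither can be ranked above the other. Going by the values given here, the one measured step, phenyl in place of acetyl on an aromatic carbon, is a 1.6-fold higher number from compound 1 to compound 2 (0.20 log units; within the scatter), which lies within the scatter.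

Compound 3 `C=C1C(=O)O[C@H]2CC3=C[C@H](C/C(C)=C/[C@@H](OC(=O)CCl)[C@H]12)OC3=O` keeps the core of compound 1 but has not yet been measured in this assay. The change is chloromethyl in place of 4-acetylphenyl on a carbonyl carbon. The measured step altered only a group on the aromatic ring, whereas here the whole 4-acetylphenyl leaves, so that step bears on this change only weakly. Among the compounds with values here, no measured compound shows the effect of this larger exchange.

The best anchor is therefore compound 1 itself, at 2200 nM, and no step beyond the scatter is expected in this assay, though with wide uncertainty. The expected step is a 1.2-fold lower number from compound 1 to compound 3 (0.09 log units; within the scatter). For compound 3 the estimated value is 1800 nM, with an expected range of 700 nM to 4500 nM.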

Compound 3, half-maximal inhibitory concentration: > 10000 nM
Compound 3: only a limit was reported; the forecaster's own chance of this, stated with the estimate: 5%; middle value at least 5.5-fold (0.74 log units) away from the limit.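

In this assay, the step between compound 1 and compound 2 had shown only a change on the aromatic ring, and that stayed within the scatter; exchanging the whole 4-acetylphenyl for chloromethyl on the carbonyl carbon goes beyond it, with an at least 4.5-fold higher number from compound 1 to compound 3 (0.65 log units; beyond the scatter). The group on this carbonyl carbon therefore matters in this assay in a way the ring substituents shown so far did not reveal: compound 1 and compound 2 both keep an aromatic ring there, whereas compound 3 has no ring and carries only chloromethyl. The step is bounded on one side only, as compound 3 carries a limit and not a number: the limit of > 10000 nM in this assay, at which 1 of the 3 values shown sits.

The compounds shown leave open whether the loss of the aromatic ring or the arrival of the chlorine carries this step, as the one exchange does both. They also do not show how a plain methyl, a longer alkyl chain or a chain ending in an amine would read on this carbonyl carbon.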